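A few compounds are considered here, and "the series" means these few. Any claim that something is new, unique, unknown or untested is made for them only; others in the source may bear on it.

Measured in a functional assay on HeLa cells (Homo sapiens) for cytotoxicity, read by MTT assay; on this read-out lower numbers stand for stronger inhibition and higher numbers for weaker inhibition:
- Compound 1 `CC[C@](C)(O)CC(=O)O[C@H](CC=C(C)C)C1=CC(=O)c2c(O)ccc(O)c2C1=O`: 30200 nM
- Compound 2 `CCC(O)CO[C@H](CC=C(C)C)C1=CC(=O)c2c(O)ccc(O)c2C1=O`: 28700 nM
- Compound 3 `CC[C@@](C)(O)CC(=O)O[C@H](CC=C(C)C)C1=CC(=O)c2c(O)ccc(O)c2C1=O`: 17900 nM

Compound 3 does not stand apart from the other two: the data show a 1.7-fold lower number from compound 1 to compound 3 (0.23 log units; within the scatter) and a 1.6-fold lower number from compound 2 to compound 3 (0.21 log units; within the scatter). Compound 4 `CCCC(C)(O)CC(=O)O[C@H](CC=C(C)C)C1=CC(=O)c2c(O)ccc(O)c2C1=O` carries 1-hydroxy-1-methylbutyl in place of 1-hydroxy-1-methylpropyl on a saturated chain carbon bound to a carbonyl carbon, that is, 1-hydroxy-1-methylbutyl in place of 1-hydroxy-1-methylpropyl on a saturated chain carbon bound to a carbonyl carbon. Going by the values given here, no measured step lengthens this chain. The closest guides are the other changes in this part of the molecule, which stayed small: a 1.1-fold lower number from compound 1 to compound 2 (0.02 log units; within the scatter), and, with the fact that compounds 1 and 3 differ only in the configuration as drawn, the step already given for that pair. In this assay, no step beyond the scatter is therefore expected, and the estimated change is a 1.2-fold higher number from compound 3 to compound 4 (0.09 log units; within the scatter). The estimate for compound 4 is 22000 nM, with an expected range of 11000 nM to 42000 nM.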

Compound 4, half-maximal inhibitory concentration: 72000 nM
Estimate against measurement, compound 4: 3.3-fold (0.51 log units) below, and the stated range ends below it.
By their numbers in this assay, from the lowest: compounds 3, 2 and 1 (each within the scatter of the next); then compound 4.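

In this assay, going by these compounds alone, 1-hydroxy-1-methylbutyl in place of 1-hydroxy-1-methylpropyl gives the first steps beyond the scatter at this position: a 4.0-fold higher number from compound 3 to compound 4 (0.60 log units; beyond the scatter) and a 2.4-fold higher number from compound 1 to compound 4 (0.38 log units; beyond the scatter). Against the 2-hydroxybutyl ether, the result is a 2.5-fold higher number from compound 2 to compound 4 (0.40 log units; beyond the scatter), which is also beyond the scatter. The position therefore responds to the chain extension, whereas the earlier differences, including that of configuration, stayed within the scatter: the fact that compounds 1 and 3 differ only in the configuration as drawn

From the compounds shown here alone, whether a longer chain such as 1-hydroxy-1-methylpentyl would raise the number further remains open. Going by these compounds, compound 4 has no defined configuration at this carbon, so whether configuration matters with the longer chain is also open.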